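From piperazin-1-yl to 4-methylpiperazin-1-yl in compound 3

The compounds below may be only part of what the source reports. "The series", "measured", "known", "first", "only" and "open" are said of these compounds alone.

Measured in an ADME assay on HOS cells (Homo sapiens) for cytotoxicity; a higher number here means that more compound is tolerated, a lower number that less compound is tolerated:
Compound 1 `CN(Cc1nc2cccc(C(=O)NCCCN)c2[nH]1)C1CCCc2cccnc21`: > 20000 nM (a limit)
Compound 2 `CN(Cc1nc2cccc(N3CCNCC3)c2[nH]1)C1CCCc2cccnc21`: > 20000 nM (a limit)

Compound 2 stands at > 20000 nM, which is a limit of the assay and not a number. Compound 3 `CN1CCN(c2cccc3nc(CN(C)C4CCCc5cccnc54)[nH]c23)CC1` carries methyl in place of hydrogen on an amine nitrogen in a ring. Going by the values given here, the only measured step, a step that the two limits leave unreadable from compound 1 to compound 2, offers no size to carry over, and the evidence amounts to the limit of > 20000 nM in this assay, at which 2 of the 2 values shown sit. No step beyond the scatter is therefore expected in this assay, and the estimated step is a number no higher from compound 2 to compound 3 (the limit leaves the size open). Compound 3 is expected at about 20000 nM, with an estimated range of 10000 nM to 40000 nM.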

Compound 3, half-maximal cytotoxic concentration: 14000 nM
Beside the measured number, compound 3's estimate is 1.4-fold (0.15 log units) above it; low and high end bracket the measured number.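

In this assay, going by these compounds alone, compound 3 gives 14000 nM, the first value in this set that is a number and not a limit of the assay. Methyl on the ring amine nitrogen appears as an at least 1.4-fold lower number from compound 2 to compound 3 (0.15 log units; that floor lies within the scatter), while the exchange of the whole group appears as an at least 1.4-fold lower number from compound 1 to compound 3 (0.15 log units; that floor lies within the scatter). Both steps are floors, so their true size stays open, because the two earlier compounds give no number to measure from: the limit of > 20000 nM in this assay, at which 2 of the 3 values shown sit.

The compounds shown leave open how ethyl or acetyl on that ring nitrogen would read in this assay. They also leave open how a longer chain on the same nitrogen would read.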